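A Demethylation Step Tested on Two Related Compounds

A few compounds are considered here, and "the series" means these few. Any claim that something is new, unique, unknown or untested is made for them only; others in the source may bear on it.

The comparison here covers measured compounds and one not yet tested. Compound 1 `COc1cc(-c2nn(-c3cccc(NC(=O)Nc4cc(C(F)(F)F)cc(C(F)(F)F)c4)c3)cc2-c2ccncc2)ccc1Cl` and compound 2 `COc1cc(-c2nn(-c3cccc(NC(=O)Nc4ccc(Cl)c(Cl)c4)c3)cc2-c2ccncc2)ccc1Cl` share much of their structure; the difference between the two cores is not broken down here. In a functional assay on 786-0 cells (Homo sapiens) for inhibition, read by sulforhodamine B assay, with a stated time of 48 h (on this read-out lower numbers stand for stronger inhibition of growth and higher numbers for weaker inhibition of growth), compound 1 gives 950 nM, and compound 2 gives 1310 nM, two numbers that lie within the scatter of each other. Compound 3 `O=C(Nc1cccc(-n2cc(-c3ccncc3)c(-c3ccc(Cl)c(O)c3)n2)c1)Nc1ccc(Cl)c(Cl)c1` arises from compound 2 by the change (hydrogen in place of methyl on an oxygen on an aromatic ring); in this assay compound 3 gives 7220 nM, and the step is a 5.5-fold higher number from compound 2 to compound 3 (0.74 log units; beyond the scatter). Compound 4 `O=C(Nc1cccc(-n2cc(-c3ccncc3)c(-c3ccc(Cl)c(O)c3)n2)c1)Nc1cc(C(F)(F)F)cc(C(F)(F)F)c1`, not yet measured, arises from compound 1 by the same change, (hydrogen in place of methyl on an oxygen on an aromatic ring), at a place described in identical words. Among the compounds with values here, only one instance of this change has been measured, so the expectation rests on compound 2 and compound 3 alone. Because the step of a 5.5-fold higher number from compound 2 to compound 3 (0.74 log units; beyond the scatter) weakened growth inhibition clearly, compound 4 is expected to show a similar step, a 5.5-fold higher number from compound 1 to compound 4 (0.74 log units; beyond the scatter), in this assay. Compound 4 is therefore estimated at 5200 nM, with a likely range from 2400 nM to 11000 nM.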

Compound 4, concentration for 50% growth inhibition: 1170 nM
Beside the measured number, compound 4's estimate is 4.4-fold (0.65 log units) above it, and the stated range ends above it.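

On the core of compound 1, the exchange of methoxy for hydroxy produced no shift that stands clear of the scatter in this assay, with a 1.2-fold higher number from compound 1 to compound 4 (0.09 log units; within the scatter). The same exchange had clearly weakened growth inhibition on the core of compound 2, so the size of the step did not carry from one core to the other, and the two steps differ: the same change on two cores in this assay, a 5.5-fold higher number (0.74 log units; beyond the scatter) from compound 2 to compound 3 and a 1.2-fold higher number (0.09 log units; within the scatter) from compound 1 to compound 4, 4.5-fold (0.65 log units) apart, beyond the scatter of two such steps. This shows that, in this series, a step measured on one core is not a safe guide to its size on the other, but two pairs do not show which part of the cores sets the steps apart, nor how the change would behave on a further core.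

The compounds shown leave open whether the outcome follows the part in which the two cores differ or some other feature of the whole molecule. From the compounds shown here alone, it also remains open whether an ethoxy group or an amine in the place of the methoxy would behave as in the pair of compound 1 or in that of compound 2.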